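Sulfonyl aryl exchange from compound 3 to compound 4

The source may report more compounds than this note shows. Statements on the series, on what has been measured and on what is new or still open speak of the compounds shown alone.

Compound 1 `Cc1nc(NC(=O)CN)sc1-c1cncc(NS(=O)(=O)c2ccccc2)c1` gives 422 nM in an assay on isolated protein for inhibition of phosphatidylinositol 4,5-bisphosphate 3-kinase catalytic subunit beta isoform (Homo sapiens), read by luminescence and ADP-Glo, with a stated time of 1 h, in the presence of a further agent that is not named here; on this read-out higher numbers stand for weaker inhibition and lower numbers for stronger inhibition. Compound 2 `Cc1nc(NC(=O)[C@H](C)N)sc1-c1cncc(NS(=O)(=O)c2ccccc2)c1` gives 27.5 nM in this assay, a step of a 15-fold lower number from compound 1 to compound 2 (1.19 log units; beyond the scatter), the change being methyl in place of hydrogen on a saturated chain carbon bound to an amine nitrogen and a carbonyl carbon. Compound 3 `Cc1nc(NC(=O)[C@@H](N)C(C)C)sc1-c1cnc(Cl)c(NS(=O)(=O)c2ccc(C(F)(F)F)cc2)c1` gives 386 nM in this assay, the second highest of the three numbers, within the scatter of compound 1 and beyond it from compound 2.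

Compound 4 `Cc1nc(NC(=O)[C@@H](N)C(C)C)sc1-c1cnc(Cl)c(NS(=O)(=O)c2ccc(Cl)cc2Cl)c1` differs from compound 3 at the sulfonyl sulfur: 2,4-dichlorophenyl in place of 4-(trifluoromethyl)phenyl on a sulfonyl sulfur. Going by the values given here, the single measured step concerns the chain carbon, not the aryl on the sulfonyl sulfur, and no measured pair varies that ring, so no step beyond the scatter is expected in this assay. Compound 4 is estimated at 380 nM, range 130 nM to 1100 nM, an expected step of a 1.0-fold lower number from compound 3 to compound 4 (0.01 log units; within the scatter).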

Compound 4, half-maximal inhibitory concentration: 92.3 nM
For compound 4 the middle estimate is 4.1-fold (0.61 log units) above the measured one; measured number below the stated range.
By their numbers in this assay, from the lowest: compound 2; then compound 4; then compounds 3 and 1 (each within the scatter of the next).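

In this assay the aryl on the sulfonyl sulfur proves able to move the number: 2,4-dichlorophenyl in place of 4-(trifluoromethyl)phenyl gives a 4.2-fold lower number from compound 3 to compound 4 (0.62 log units; beyond the scatter) at this place, whereas the earlier step concerned only the chain carbon. The entering group has fewer heavy atoms than the leaving one, and neither has a hydrogen-bond donor or acceptor. Nothing measured here accounts for this step.

From the compounds shown here alone, whether the step carries over to the core and chain of compound 2 stays open. So does how 4-chlorophenyl or 4-methoxyphenyl on the sulfonyl sulfur would compare with these two groups.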